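Notes on a small imidazole series at the alpha-1B receptor

A few compounds are considered here, and "the series" means these few. Any claim that something is new, unique, unknown or untested is made for them only; others in the source may bear on it.

Measured so far:
compound 1 `COc1cccc(C2CCc3nc[nH]c3C2)c1`: > 10000 nM
compound 2 `Clc1cccc(C2CCc3nc[nH]c3C2)c1`: > 10000 nM
compound 3 `COc1ccccc1C1Cc2nccn2C1`: "not determined" (no result reported)

In a functional assay on CHO cells for agonist activity at Alpha-1B adrenergic receptor (Homo sapiens), read by FLIPR and calcium flux (on this read-out higher numbers stand for an effect only at larger amounts of compound and lower numbers for an effect already at smaller amounts), compound 1 reaches only a limit, > 10000 nM. Compound 2 likewise reaches only a limit in this assay, > 10000 nM. The change between them, (chloro in place of methoxy on an aromatic carbon), therefore gives a step that the two limits leave unreadable from compound 1 to compound 2; both values sit at the limit of > 10000 nM in this assay, at which 2 of the 3 values shown sit. For compound 3 the record in this assay reads "not determined" (no result reported), so no number is available for it. The difference between the core of compound 3 and the core of compound 1 is not broken down here.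

Compound 4 `Clc1ccccc1C1Cc2nccn2C1` is not yet measured. From compound 3 it differs by chloro in place of methoxy on an aromatic carbon, the same kind of change as from compound 1 to compound 2, though the place is ortho to a group of 8 heavy atoms rather than meta to a group of 9 heavy atoms. With compound 1 and compound 2 both at a limit in this assay, compound 4 is expected to lie near 8000 nM, within 1000 nM to 30000 nM, with a fair chance that only a limit is reported.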

Compound 4, half-maximal effective concentration in the Alpha-1B adrenergic receptor assay: 1100 nM
For compound 4 the middle estimate is 7.3-fold (0.86 log units) above the measured one; measured number inside the range.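

In the Alpha-1B adrenergic receptor assay compound 3 reads "not determined" (no result reported) and compound 4 gives 1100 nM so no new step can be read between compound 3 and compound 4. Left open is what chloro in place of methoxy does in the Alpha-1B adrenergic receptor assay on the core of compound 3, and how that core compares with the core of compound 1. In a physicochemical assay for lipophilicity, at pH 7.4 (on this read-out lower numbers stand for lower lipophilicity and higher numbers for higher lipophilicity), compound 3 gives 1.9 and compound 4 gives 2.6 as measured values.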